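The source may hold more compounds than are shown below. What is called first, only, known or untested is meant among the compounds shown, and "the series" means these compounds.

Compound 1 `C#Cc1cn([C@@H]2O[C@H](CO)[C@@H](O)[C@H]2O)c2ncnc(C)c12`: in a functional assay on HCT-116 cells (Homo sapiens), read by MTT assay, with a stated time of 72 h (a lower number here means a stronger inhibitor, a higher number a weaker inhibitor), compound 1 only reaches the assay limit, > 20000 nM.
Compound 2 `Cc1ncnc2c1c(-c1cc3ccccc3o1)cn2[C@@H]1O[C@H](CO)[C@@H](O)[C@H]1O`: in this assay compound 2 likewise only reaches the assay limit, > 20000 nM.
Compound 3 `Cc1ncnc2c1c(-c1ccoc1)cn2[C@@H]1O[C@H](CO)[C@@H](O)[C@H]1O`: in this assay compound 3 also only reaches the assay limit, > 20000 nM.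

Compound 2 thus stands where every measured compound stands, at the limit of > 20000 nM in this assay, at which 3 of the 3 values shown sit. Its steps to its neighbours, a step that the two limits leave unreadable from compound 1 to compound 2 and a step that the two limits leave unreadable from compound 2 to compound 3, cannot be read in size or direction, and the remaining step that the two limits leave unreadable from compound 1 to compound 3 is equally unreadable. Compound 4 `COc1ncnc2c1c(-c1cc3ccccc3o1)cn2[C@@H]1O[C@H](CO)[C@@H](O)[C@H]1O` differs from compound 2 by methoxy in place of methyl on an aromatic carbon. Within the data shown here, no measured step touches a methoxy, so none bears directly on this change; nothing in the three values suggests a move away from the limit. Compound 4 is therefore expected to stay at the limit, with an estimated step that the limit leaves unreadable from compound 2 to compound 4. The estimate for compound 4 is 35000 nM, between 8000 nM and 200000 nM.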

Compound 4, half-maximal inhibitory concentration: 13800 nM
Beside the measured number, compound 4's estimate is 2.5-fold (0.40 log units) above it; measured number inside the range.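

In this assay, among these compounds, methoxy in place of methyl on this aromatic carbon, next to the ring nitrogen, gives an at least 1.4-fold lower number from compound 2 to compound 4 (0.16 log units; that floor lies within the scatter) and so the first step here that can be read, while all the others cannot. That floor does not show a change beyond the scatter, yet compound 4 alone has a number rather than a limit: the limit of > 20000 nM in this assay, at which 3 of the 4 values shown sit.

On these data alone, whether an amine or an ethoxy at this position would move the number further remains open. So does whether methoxy would bring the furan-3-yl or ethynyl compounds off the limit.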